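The compounds below may be only part of what the source reports. "The series", "measured", "known", "first", "only" and "open" are said of these compounds alone.

Within the data shown here, compound 1 `CN(C(=O)C[C@@H](N)CCCCN)C1CN=C(NC(N)=O)NC1=O` sits at the weak end of the three numbers measured so far: in a functional assay for inhibition, with Oryctolagus cuniculus as the target (on this read-out lower numbers stand for stronger inhibition and higher numbers for weaker inhibition), compound 1 gives 2800 nM, the highest of the set. Compound 2 `CN(C(=O)C[C@@H](N)CCCCN)C1CN=C(Nc2ncccn2)NC1=O` gives 380 nM in this assay, and compound 3 `CN(C(=O)C[C@@H](N)CCCCN)C1CN=C(Nc2ccccn2)NC1=O` gives 200 nM. Both steps away from compound 1 run in one direction: a 7.4-fold lower number from compound 1 to compound 2 (0.87 log units; beyond the scatter) and a 14-fold lower number from compound 1 to compound 3 (1.15 log units; beyond the scatter). Between the two aromatic replacements the gap is small, a 1.9-fold lower number from compound 2 to compound 3 (0.28 log units; within the scatter). Compound 4 `CN(C(=O)C[C@@H](N)CCCCN)C1CN=C(Nc2ccc3ccccc3n2)NC1=O` has not yet been measured in this assay. Its change from compound 1 is as follows.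

quinolin-2-yl in place of carbamoyl on an amine nitrogen

Among the measured compounds shown here, the two measured steps that bear on this one replace the carbamoyl on the same amine nitrogen with pyrimidin-2-yl and with pyridin-2-yl, and both lower the number well beyond the scatter, so a lowering of similar size is expected here; no measured compound shows how the second ring of quinolin-2-yl is tolerated, so the range is kept wide. The step expected is a 19-fold lower number from compound 1 to compound 4 (1.27 log units; beyond the scatter). Compound 4 is estimated at 150 nM in this assay, with a range from 40 nM to 600 nM.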

Compound 4, half-maximal inhibitory concentration: 50 nM
Compound 4: the middle estimate sits 3.0-fold (0.48 log units) above what was measured; the range from low to high includes it.
By their numbers in this assay, from the lowest: compound 4; then compounds 3 and 2 (each within the scatter of the next); then compound 1.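

On this amine nitrogen, a second aromatic ring is not only tolerated but gives a lower number than either single-ring group: in this assay, quinolin-2-yl gives a 4.0-fold lower number from compound 3 to compound 4 (0.60 log units; beyond the scatter) and a 7.6-fold lower number from compound 2 to compound 4 (0.88 log units; beyond the scatter), whereas pyridin-2-yl and pyrimidin-2-yl stand within the scatter of each other. Against carbamoyl, the full change amounts to a 56-fold lower number from compound 1 to compound 4 (1.75 log units; beyond the scatter), the largest step among these four compounds, so the aromatic replacements at this position are no longer confined to one narrow band of values. Nothing at hand bears on what lies behind the gain from the second ring.

On these data alone, whether the ring nitrogen of quinolin-2-yl is needed stays open, and a naphthalen-2-yl on the same amine nitrogen would address that. Also open, as far as these compounds go, is whether a methoxy or an amine on the second ring would keep the lower number.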